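Removing the ethoxy from the amide aryl group

This account rests on a few compounds, and the source may have more. Where it says the series, first, only, none or still open, it means among the compounds named here.

Compound 2 `C=CC1=C(C(=O)Nc2ccc(OCC)cc2)C(c2ccc(OC)cc2)OC1` is an amide whose nitrogen carries a 4-ethoxyphenyl group. In a functional assay on SW480 cells (Homo sapiens) for cytotoxicity, read by MTT assay, with a stated time of 24 h (a higher number here means a weaker inhibitor, a lower number a stronger inhibitor), compound 2 gives only a limit of the assay, > 100000 nM. Its companion compound 1 `C=CC1=C(C(=O)NC(C)(C)C)C(c2ccc(OC)cc2)OC1` carries tert-butyl on that nitrogen instead. In this assay compound 1 likewise reaches only a limit, > 100000 nM. The step that the two limits leave unreadable from compound 1 to compound 2 therefore cannot be read, since (the limit of > 100000 nM in this assay, at which 2 of the 2 values shown sit). Compound 3 `C=CC1=C(C(=O)Nc2ccccc2)C(c2ccc(OC)cc2)OC1` differs from compound 2 by hydrogen in place of ethoxy on an aromatic carbon. No measured step bears on this change, and the single step shown gives no number to lean on. From the compounds shown here alone, the effect of removing the ethoxy is unknown from these compounds, so nothing beyond the limit is expected. Compound 3 is expected to stay at the edge of the assay, a step of a number no higher from compound 2 to compound 3 (the limit leaves the size open) that is small to nil. Compound 3 is estimated at 100000 nM, with a range from 30000 nM to 300000 nM.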

Compound 3, half-maximal inhibitory concentration: > 100000 nM
Compound 3: no number, only a limit; the forecaster's own chance of this, stated with the estimate: 80%; the middle value sits exactly at the limit.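

Going by these compounds alone, no step among compound 1, compound 2 and compound 3 can be read in this assay, because each gives only a limit: the limit of > 100000 nM in this assay, at which 3 of the 3 values shown sit. The compounds shown leave open whether tert-butyl, 4-ethoxyphenyl and phenyl on the amide nitrogen differ in their effect at all.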